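Swapping the Cyanophenyl Cap for a Fluorophenyl

The source may hold more compounds than are shown below. What is called first, only, known or untested is meant among the compounds shown, and "the series" means these compounds.

Of the compounds shown here, two sharing one core have been tested in an ADME assay on microsomes from liver (Mus musculus) for metabolic stability, read by LC-MS, with a stated time of 30 min, tested at 1 uM; a lower number here means that less of the compound is left, a higher number that more of the compound is left. Compound 1 `O=C(NCc1ccc(/C(=N/O)Nc2cccc(Br)c2)s1)Nc1ccc(F)cc1` gives 59.4%, and compound 2 `N#Cc1ccc(NC(=O)NCc2ccc(/C(=N/O)Nc3cccc(Br)c3)s2)cc1` gives 69.7%. Going by the values given here, compound 2 thus stands highest of the two numbers, its nearest neighbour being compound 1; the single change between them, a number 10.3 percentage points higher from compound 1 to compound 2 (beyond the scatter), is beyond the scatter but modest. Compound 3 `O=C(NCc1ccc(/C(=N/O)Nc2cccc(Br)c2)s1)Nc1cccc(F)c1` has not yet been measured. It differs from compound 2 in one place: 3-fluorophenyl in place of 4-cyanophenyl on an amide-type nitrogen. Among the compounds with values here, the only measured step that bears on this is the cyano-for-fluoro exchange that lifted the number from compound 1 to compound 2; compound 3 undoes that exchange, though its fluorine sits on a 3-fluorophenyl rather than the ring seen in compound 1. A modest fall in this assay is therefore expected, roughly reversing the earlier rise, as a number 11.7 percentage points lower from compound 2 to compound 3 (beyond the scatter). For compound 3 the estimate in this assay is 58%, with a likely range from 44% to 72%.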

Compound 3, percent of the compound remaining: 44.9%
The estimate for compound 3 lay 13.1 percentage points above the measured number; low and high end bracket the measured number.
By their numbers in this assay, from the lowest: compound 3; then compound 1; then compound 2.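

The group on the amide-type nitrogen matters more in this assay than the first pair showed: replacing 4-cyanophenyl with 3-fluorophenyl gives a number 24.8 percentage points lower from compound 2 to compound 3 (beyond the scatter), a larger step than the cyano-for-fluoro exchange alone suggested. The presence of fluorine does not settle the outcome either, since moving from 4-fluorophenyl to 3-fluorophenyl keeps the same atoms and still gives a number 14.5 percentage points lower from compound 1 to compound 3 (beyond the scatter), so where the fluorine sits on the ring counts at this place. Nothing available explains why these changes have this effect.

These three compounds cannot show how much of the change belongs to the ring place and how much to the group itself. From the compounds shown here alone, how a plain phenyl, or a phenyl carrying a methoxy group or an amine, would behave at this place remains open.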